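Replacing the Pyrimidin-2-yl Group on the Shared Core

The source may report more compounds than this note shows. Statements on the series, on what has been measured and on what is new or still open speak of the compounds shown alone.

Two measured compounds share one core. Compound 1 `Cc1nc(-c2ccccc2NCC2=NCCN2)cs1` carries a 2-methyl-1,3-thiazol-4-yl group, and in a functional assay for activation of Alpha-1B adrenergic receptor (Homo sapiens), read by calcium flux (on this read-out higher numbers stand for an effect only at larger amounts of compound and lower numbers for an effect already at smaller amounts), compound 1 gives 69.2 nM. Compound 2 `c1cnc(-c2ccccc2NCC2=NCCN2)nc1` carries a pyrimidin-2-yl group in its place, and in this assay compound 2 gives 77.6 nM. Going by the values given here, compound 2 thus stands with the higher of the two numbers, its only neighbour being compound 1, and the step of a 1.1-fold higher number from compound 1 to compound 2 (0.05 log units; within the scatter) lies within the scatter, so the two values cannot be told apart.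

Compound 3 `CO/N=C/c1ccccc1NCC1=NCCN1` is not yet measured. It differs from compound 2 by a group of 4 heavy atoms (2 carbon, 1 nitrogen, 1 oxygen; no ring) in place of a group of 6 heavy atoms (4 carbon, 2 nitrogen; one six-membered aromatic ring with 2 hetero atoms), on an aromatic carbon. Among the compounds with values here, the one measured step that bears on this position is a 1.1-fold higher number from compound 1 to compound 2 (0.05 log units; within the scatter), in which one aromatic ring was exchanged for another without a change beyond the scatter. The entering group has no ring, so that step is only a partial guide, and the range is therefore set wide. For compound 3 the expected value in this assay is 90 nM, within an estimated range from 30 nM to 300 nM. The estimated step of a 1.2-fold higher number from compound 2 to compound 3 (0.06 log units; within the scatter) is expected to stay small.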

Compound 3, half-maximal effective concentration: < 5020 nM
Compound 3: no number, only a limit; the forecaster's own chance of this, stated with the estimate: 5%; the middle value lies beyond the limit too.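

In this assay compound 3 gives < 5020 nM, which is a limit of the assay and not a number. The steps from compound 1 and from compound 2 to compound 3 cannot be read. The compounds shown leave open whether replacing either aromatic ring with the group that has no ring changes the value at all.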